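This account rests on a few compounds, and the source may have more. Where it says the series, first, only, none or still open, it means among the compounds named here.

The series shares one core and differs in the group on a carbon with a double bond to nitrogen. Compound 1 (`COc1cc2ncnc(Nc3ccc(F)c(Cl)c3)c2cc1NC(=O)N/N=C/c1cccc(Br)c1`) is reported in a functional assay on PC-3 cells (Homo sapiens) for cytotoxicity, read by MTT assay, with a stated time of 72 h (a lower number here means a stronger inhibitor, a higher number a weaker inhibitor), as "not active" (no number reported) with no number given. Going by the values given here, compound 2 (`COc1cc2ncnc(Nc3ccc(F)c(Cl)c3)c2cc1NC(=O)N/N=C/c1ccc([N+](=O)[O-])cc1`) gives 32400 nM in this assay and compound 3 (`COc1cc2ncnc(Nc3ccc(F)c(Cl)c3)c2cc1NC(=O)N/N=C/c1cccc(Cl)c1Cl`) gives 24400 nM in the same test, so compound 3 sits within the scatter of compound 2, the only other compound with a number.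

The next entry is compound 4 (`COc1cc2ncnc(Nc3ccc(F)c(Cl)c3)c2cc1NC(=O)N/N=C/c1ccc(OC)c(OC)c1OC`), and the change that leads to it is 2,3,4-trimethoxyphenyl in place of 2,3-dichlorophenyl on a carbon with a double bond to nitrogen in the same place. Among the compounds with values here, the one measured step is a 1.3-fold lower number from compound 2 to compound 3 (0.12 log units; within the scatter) and it gives no ground for expecting a large move. Compound 1 at "not active" (no number reported) shows that a number is not assured at this place. Within the data shown here, no measured compound carries 2,3,4-trimethoxyphenyl, so the range stays wide.

In this assay no shift beyond the scatter is expected, and the estimated step is a 1.1-fold higher number from compound 3 to compound 4 (0.06 log units; within the scatter) as a central guess. For compound 4 the estimate is 28000 nM with an expected range of 10000 nM to 80000 nM if a number is reported at all.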

Compound 4, half-maximal inhibitory concentration: 29300 nM
Estimate against measurement, compound 4: 1.0-fold (0.02 log units) below; the measured number falls inside the stated range.
By their numbers in this assay, from the lowest: compounds 3, 4 and 2 (each within the scatter of the next).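

In this assay, 2,3,4-trimethoxyphenyl in place of 2,3-dichlorophenyl on a carbon with a double bond to nitrogen gives a 1.2-fold higher number from compound 3 to compound 4 (0.08 log units; within the scatter), even though the entering group has 12 heavy atoms against 8 and 3 hydrogen-bond acceptors against 0. Set against 4-nitrophenyl, the same group gives a 1.1-fold lower number from compound 2 to compound 4 (0.04 log units; within the scatter), so compounds 2, 3 and 4 now form a set of three that this read-out does not separate, and a change of this size in the group leaves the number within the scatter; compound 1 stands outside that set, as it has no number to compare. The data on hand offer no measurement that bears on why these three groups give values within the scatter of one another.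

It remains open whether any group at this place can move the number beyond the scatter, since all the groups shown are substituted phenyl rings and none carries an amine or a carboxylic acid, nor is a saturated alkyl chain among them. Going by these compounds, it also remains open whether the missing number for compound 1 is tied to its bromine.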